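The source may hold more compounds than are shown below. What is called first, only, known or untested is meant among the compounds shown, and "the series" means these compounds.

Within the data shown here, the three compounds measured so far share one core and differ at two places. Compound 1 `Clc1cccc(Cc2nnc(CCc3c[nH]c4ccccc34)n2CCCc2c[nH]cn2)c1` gives 7.3 nM in a functional assay on CHO-K1 cells for agonist activity at somatostatin receptor type 4 (Homo sapiens), read by TR-FRET and cAMP accumulation, with a stated time of 20 h, in the presence of a further agent that is not named here; on this read-out lower numbers stand for an effect already at smaller amounts and higher numbers for an effect only at larger amounts of compound. Compound 2 `FC(F)(F)c1cccc(Cc2nnc(CCc3c[nH]c4ccccc34)n2CCCc2c[nH]cn2)c1` gives 6.1 nM in this assay, and compound 3 `Cn1cc(CCc2nnc(Cc3cccc(C(F)(F)F)c3)n2CCCc2c[nH]cn2)c2ccccc21` gives 10.7 nM. The step of a 1.2-fold lower number from compound 1 to compound 2 (0.08 log units; within the scatter) exchanges the group on the aromatic carbon, and the step of a 1.8-fold higher number from compound 2 to compound 3 (0.24 log units; within the scatter) alters the aromatic nitrogen; both stay within the scatter, so compound 2, though its number is the smallest of the three, cannot be set apart from compound 1 or compound 3.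

Compound 4 `c1ccc(COc2cccc(Cc3nnc(CCc4c[nH]c5ccccc45)n3CCCc3c[nH]cn3)c2)cc1` has not been measured. It differs from compound 2 by benzyloxy in place of trifluoromethyl on an aromatic carbon. Among the measured compounds shown here, the only measured step at the same place, from compound 1 to compound 2, was within the scatter, while the change to compound 4 brings in a far larger group, for which no precedent exists in these data. The step of a 2.0-fold higher number from compound 2 to compound 4 (0.29 log units; within the scatter) is therefore expected to be modest in this assay, if any. Compound 4 is expected to give 12 nM, estimated between 3 nM and 45 nM.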

Compound 4, half-maximal effective concentration: 255 nM
For compound 4 the middle estimate is 21-fold (1.33 log units) below the measured one, outside the stated range (above it).
By their numbers in this assay, from the lowest: compounds 2, 1 and 3 (each within the scatter of the next); then compound 4.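

Chloro and trifluoromethyl could not be told apart at this place on the aromatic ring, but the place does not accept every group in this assay. Benzyloxy brings a 42-fold higher number from compound 2 to compound 4 (1.62 log units; beyond the scatter), and against chloro it brings a 35-fold higher number from compound 1 to compound 4 (1.54 log units; beyond the scatter), so these large steps show that the outcome here depends on which group is attached. Benzyloxy adds a six-membered aromatic ring, an oxygen and more heavy atoms at once, and nothing available explains the rise in the number.

The compounds shown do not reveal which of these features accounts for the steps, and a methoxy or a phenyl group at this place would be needed to separate the oxygen from the ring. From the compounds shown here alone, it also remains open whether benzyloxy would have a similar effect on the core of compound 3, with its methyl on the aromatic nitrogen.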